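A few compounds are considered here, and "the series" means these few. Any claim that something is new, unique, unknown or untested is made for them only; others in the source may bear on it.

Measured so far in a functional assay on CCRF-CEM cells (Homo sapiens) for antiproliferative activity, read by cell counting, with a stated time of 2 days; on this read-out lower numbers stand for stronger inhibition and higher numbers for weaker inhibition:
compound 1 `COc1ccc(Nc2nc(N)c(C(=O)c3ccc(Br)cc3)s2)cc1` gives 39 nM
compound 2 `COc1ccc(Nc2nc(N)c(C(=O)c3ccc([N+](=O)[O-])cc3)s2)cc1` gives 31 nM

Among the compounds with values here, compound 1 stands within the scatter of compound 2, the only other measured compound. The step is a 1.3-fold lower number from compound 1 to compound 2 (0.10 log units; within the scatter), so the two cannot be ordered.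

Still unmeasured is compound 3 `COc1ccc(Nc2nc(N)c(C(=O)c3ccccc3OC)s2)cc1`. Its difference from compound 1 is 2-methoxyphenyl in place of 4-bromophenyl on a carbonyl carbon, with 2-methoxyphenyl in place of 4-bromophenyl on a carbonyl carbon. Within the data shown here, only one measured step is available, nitro in place of bromo on an aromatic carbon, and it bears on this change only loosely. That step stayed within the scatter, but it replaced a single group on the aromatic ring, whereas here the whole 4-bromophenyl leaves. Among the measured compounds shown here, no measured compound carries a 2-methoxyphenyl, so the data fix neither the size nor the direction of the change. A moderate move to a higher number in this assay is expected, though this is held loosely and the range is kept wide. The expected step is a 2.6-fold higher number from compound 1 to compound 3 (0.41 log units; beyond the scatter). For compound 3 the estimated value is 100 nM, with an expected range from 20 nM to 600 nM.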

Compound 3, half-maximal inhibitory concentration: 17 nM
The estimate for compound 3 lay 5.9-fold (0.77 log units) above the measured number; measured number outside the range, below it.
By their numbers in this assay, from the lowest: compounds 3, 2 and 1 (each within the scatter of the next, the first and the last beyond it).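

In this assay, replacing the whole aryl group on the carbonyl carbon moves the number: with 2-methoxyphenyl in place of 4-bromophenyl there is a 2.3-fold lower number from compound 1 to compound 3 (0.36 log units; beyond the scatter). Within the data shown here, the earlier step, a 1.3-fold lower number from compound 1 to compound 2 (0.10 log units; within the scatter), exchanged only one group on the aromatic ring and could not be ordered, so this is the first change that can be read, and it shows that the 4-bromophenyl is not required for a value in this range, since compound 3, which carries no bromine, gives 17 nM. Nothing at hand bears on the reason for this step.

The change alters both the group on the ring and its place in one move, so the compounds shown cannot separate the two. Unsubstituted phenyl, 4-methoxyphenyl and 2-bromophenyl on the same carbonyl carbon would divide the step into its parts, and 2-ethoxyphenyl, with its longer chain, would show whether the 2-methoxyphenyl value holds when that group grows.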